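Moving the Halogen on the Hydrazone Aryl Ring

A few compounds are considered here, and "the series" means these few. Any claim that something is new, unique, unknown or untested is made for them only; others in the source may bear on it.

The shared core carries an acylhydrazone whose aryl group is the only part that varies across these compounds. Compound 1 `Cc1c(C(=O)N/N=C\c2ccc(O)cc2)oc2cccc(O)c12` bears a 4-hydroxyphenyl on the carbon with a double bond to nitrogen; in a functional assay on PC-3 cells (Homo sapiens) for inhibition (a higher number here means a weaker inhibitor, a lower number a stronger inhibitor), compound 1 gives 21700 nM. Going by the values given here, compound 2 `Cc1c(C(=O)N/N=C\c2cc(Cl)ccc2O)oc2cccc(O)c12` carries a 5-chloro-2-hydroxyphenyl in that place and in this assay compound 2 gives 3120 nM, the lowest of the two numbers so far; the step of a 7.0-fold lower number from compound 1 to compound 2 (0.84 log units; beyond the scatter) is the only measured step in this set.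

Compound 3 `Cc1c(C(=O)N/N=C\c2cccc(Br)c2O)oc2cccc(O)c12` is the next variation: 3-bromo-2-hydroxyphenyl in place of 5-chloro-2-hydroxyphenyl on a carbon with a double bond to nitrogen. Among the compounds with values here, the one measured step exchanged both the position of the hydroxyl and the presence of a halogen, so it bears on this change only loosely; the new change keeps the hydroxyl and swaps one halogen for another at a different place on the ring. Within the data shown here, no measured pair isolates this kind of exchange, so a step of no more than the scatter is expected in either direction, and the estimated step from compound 2 to compound 3 is a 1.1-fold higher number from compound 2 to compound 3 (0.05 log units; within the scatter). Compound 3 is therefore expected to give about 3500 nM in this assay, with a range from 1200 nM to 10000 nM.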

Compound 3, half-maximal inhibitory concentration: 16600 nM
Compound 3: middle estimate off by 4.7-fold (0.68 log units), on the low side; measured number outside the range, above it.
By their numbers in this assay, from the lowest: compound 2; then compounds 3 and 1 (each within the scatter of the next).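

The aryl group on the carbon with a double bond to nitrogen turns out to depend on more than carrying a hydroxyl and a halogen: in this assay the exchange of 5-chloro-2-hydroxyphenyl for 3-bromo-2-hydroxyphenyl gives a 5.3-fold higher number from compound 2 to compound 3 (0.73 log units; beyond the scatter) and so undoes the earlier drop of a 7.0-fold lower number from compound 1 to compound 2 (0.84 log units; beyond the scatter). The remaining comparison, a 1.3-fold lower number from compound 1 to compound 3 (0.12 log units; within the scatter), lies within the scatter, which leaves the 3-bromo-2-hydroxyphenyl and 4-hydroxyphenyl groups indistinguishable here, and of the three compounds only compound 2 stands apart from the other two. Nothing at hand accounts for the difference between the two halogen-bearing groups.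

This single change alters both the halogen and its place on the ring, so the compounds shown do not tell which of the two governs the step, a question that 5-bromo-2-hydroxyphenyl or 3-chloro-2-hydroxyphenyl would address directly. As far as these compounds go, how a methoxy group or an amine in place of the ring hydroxyl would read in this assay also remains open.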